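The source may report more compounds than this note shows. Statements on the series, on what has been measured and on what is new or still open speak of the compounds shown alone.

Measured so far:
compound 1, `CC1(OC(=O)N2CC3COCC(C2)C3Oc2ncnc(Oc3ccccc3F)c2F)CC1`, 114%
compound 2, `N#Cc1ccc(Nc2ncnc(OC3C4COCC3CN(C(=O)OC3CCC3)C4)c2F)c(Cl)c1`, 51%

In a functional assay on HEK293 cells for agonist activity at Glucose-dependent insulinotropic receptor (Homo sapiens), read by cAMP accumulation, with a stated time of 30 min (a lower number here means a smaller maximal response, a higher number a larger maximal response), compound 1 gives 114%, the higher of the two numbers. Compound 2 gives 51%, which lies far below compound 1, beyond the scatter. Within the data shown here, no single-point step connects these two compounds; the pair shows only that the amino-linked aryl analogue reaches a much smaller maximal response than the ether of compound 1.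

Compound 3, `CC1(OC(=O)N2CC3COCC(C2)C3Oc2ncnc(Nc3cccnc3Cl)c2F)CC1`, is not yet measured. It differs from compound 1 at one place: (2-chloropyridin-3-yl)amino in place of 2-fluorophenoxy on an aromatic carbon. The change swaps the 2-fluorophenoxy ether for a (2-chloropyridin-3-yl)amino group on an aromatic carbon of the shared core. Compound 2 also carries an amino-linked aryl group and its 51% is the lower number, so a decrease is expected, though the rest of compound 3 matches compound 1 and the drop may be partial. For compound 3 the expected value in this assay is 85%, with a range from 55% to 115%. This estimate means a step of a number 29 percentage points lower from compound 1 to compound 3 (beyond the scatter), expected to be a decrease beyond the scatter.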

Compound 3, largest response reached (reported as percent of maximum), in percent of the reference or control that the assay uses: 63%
For compound 3 the middle estimate is 22 percentage points above the measured one; low and high end bracket the measured number.
By their numbers in this assay, from the lowest: compound 2; then compound 3; then compound 1.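

In this assay, among these compounds, (2-chloropyridin-3-yl)amino in place of 2-fluorophenoxy gives a number 51 percentage points lower from compound 1 to compound 3 (beyond the scatter), the only single-place comparison so far. This aromatic carbon, next to the ring nitrogen and ortho to a fluoro group, is therefore sensitive to the group it carries: with the rest of compound 1 unchanged, the maximal response falls by a large step. No measured evidence explains the size or direction of this step.

The change replaces the ether oxygen with an amine linker and the fluorophenyl ring with a chloropyridine ring in one move, so the contribution of each remains unresolved. An anilino group bearing the same fluorine, or a pyridinyloxy ether bearing the same chlorine, would separate the linker from the ring.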